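Taking One Methoxy from Compound 3

The source may hold more compounds than are shown below. What is called first, only, known or untested is meant among the compounds shown, and "the series" means these compounds.

In a functional assay on DU-145 cells (Homo sapiens) for antiproliferative activity, read by sulforhodamine B assay, with a stated time of 48 h (a higher number here means a weaker inhibitor, a lower number a stronger inhibitor), compound 1 `O=C1NCCN1c1ccc(S(=O)(=O)Nc2cccc(Br)c2)cc1` gives 340 nM and compound 2 `O=C1NCCN1c1ccc(S(=O)(=O)Nc2cccc(Cl)c2)cc1` gives 230 nM. Compound 3 `COc1cc(NS(=O)(=O)c2ccc(N3CCNC3=O)cc2)cc(OC)c1`, at 700 nM, has the highest number of the three, beyond the scatter from both. Compound 4 `COc1cccc(NS(=O)(=O)c2ccc(N3CCNC3=O)cc2)c1` differs from compound 3 by hydrogen in place of methoxy on an aromatic carbon. Among the measured compounds shown here, no measured step covers this change. The only one, a 1.5-fold lower number from compound 1 to compound 2 (0.17 log units; within the scatter), exchanges one halogen for another and stays within the scatter. Still, compound 1 carries no methoxy group and gives 340 nM, while compound 3 gives 700 nM, so a modest shift toward lower numbers is expected, an estimated 1.7-fold lower number from compound 3 to compound 4 (0.22 log units; within the scatter). Compound 4 is estimated at 420 nM, within a range of 190 nM to 900 nM.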

Compound 4, half-maximal inhibitory concentration: 650 nM
The estimate for compound 4 lay 1.5-fold (0.19 log units) below the measured number, within the range that was stated.
By their numbers in this assay, from the lowest: compounds 2, 1, 4 and 3 (each within the scatter of the next, the first and the last beyond it).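

In this assay, hydrogen in place of methoxy gives a 1.1-fold lower number from compound 3 to compound 4 (0.03 log units; within the scatter) and so does not separate the two compounds, meaning the methoxy lost here makes no readable difference. The halogen comparisons for the methoxy that remains differ, with methoxy in place of chloro giving a 2.8-fold higher number from compound 2 to compound 4 (0.45 log units; beyond the scatter) and methoxy in place of bromo giving a 1.9-fold higher number from compound 1 to compound 4 (0.28 log units; within the scatter), so only the first of these steps can be read as a real gap. No available evidence accounts for these steps.

The compounds shown leave open how an amine, a hydroxyl or a longer chain such as ethoxy would compare at this position. They also leave open whether fluoro would follow chloro or bromo there.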